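Epimer of compound 1 in the glucosaminidase series

The source may report more compounds than this note shows. Statements on the series, on what has been measured and on what is new or still open speak of the compounds shown alone.

Compound 1 `O=C(O)[C@@H]1NCC=C[C@H]1O` carries a carboxylic acid and a hydroxyl on an unsaturated piperidine-type core. In an assay on isolated protein for inhibition of cytosolic endo-beta-N-acetylglucosaminidase (Homo sapiens), tested at 1000 uM (on this read-out higher numbers stand for more inhibition at the one concentration tested (going by the name of the read-out) and lower numbers for less inhibition), compound 1 gives 14%. Among the compounds with values here, compound 2 `O=C(O)[C@@H]1NC[C@@H](O)[C@H](O)[C@H]1O`, the saturated trihydroxylated analogue, is the only other measured member; in this assay compound 2 gives 50%. On these two numbers compound 1 stands lowest, and the gap to compound 2 lies beyond the scatter. Within the data shown here, no single-point step between measured compounds is recorded, so nothing measured tells how a change of configuration alone moves the read-out here.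

Compound 3 `O=C(O)[C@H]1NCC=C[C@H]1O` is the next compound to be tested. It differs from compound 1 as follows: the two compounds have the same atoms and bonds and differ only in configuration as drawn: 1 of 2 stereo elements differ; a stereocentre at a saturated ring carbon is drawn R in compound 1 and S in compound 3. Among the measured compounds shown here, with no measured step of this kind to lean on, the expected change from compound 1 to compound 3 is a small one, in either direction, or none beyond the scatter; the expected step is a number 1 percentage points higher from compound 1 to compound 3 (within the scatter). Compound 3 is therefore estimated at 15% in this assay, with a range from 0% to 45%.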

Compound 3, a percentage reported as inhibition, at one concentration (the size of the read-out at that concentration, not a potency): 17%
Compound 3: middle estimate off by 2 percentage points, on the low side; measured number inside the range.
By their numbers in this assay, from the lowest: compounds 1 and 3 (each within the scatter of the next); then compound 2.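

Within the data shown here, the first single-change step in this assay is a number 3 percentage points higher from compound 1 to compound 3 (within the scatter), so at this saturated ring carbon the drawn configuration, R or S, gives no difference that this read-out can separate on the unsaturated core. This step can be read as a pure test of that stereocentre, because the pair offers no other change to account for it: the fact that compounds 1 and 3 differ only in the configuration as drawn

Among these compounds, the finding is limited to inhibition at the one concentration tested, so it shows no difference in the size of the read-out at that concentration and gives no potency for either compound. It also applies only to the unsaturated core shared by compound 1 and compound 3.

Whether the same inversion would matter on the saturated, trihydroxylated core of compound 2 remains open, since that compound has no single-change partner among those shown. Also open, going by these compounds, is how the read-out would respond if a methyl ester or a primary amide took the place of the carboxylic acid, on either configuration.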